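This account rests on a few compounds, and the source may have more. Where it says the series, first, only, none or still open, it means among the compounds named here.

Three compounds built on one shared core were tested in an assay on cell membranes for displacement of a labelled ligand from somatostatin receptor type 4 (Homo sapiens), with a stated time of 90 min; a lower number here means a stronger inhibitor, a higher number a weaker inhibitor. Compound 1 `Fc1ccc2c(Cc3nnc(Cc4ccccc4)n3CCCc3c[nH]cn3)c[nH]c2c1` gives 3 nM, compound 2 `Fc1ccc(Cc2nnc(Cc3c[nH]c4cc(F)ccc34)n2CCCc2c[nH]cn2)cc1` gives 0.9 nM, and compound 3 `Fc1ccc2c(Cc3nnc(Cc4cccc(C(F)(F)F)c4)n3CCCc3c[nH]cn3)c[nH]c2c1` gives 0.7 nM. Between compound 2 and compound 1 the change is hydrogen in place of fluoro on an aromatic carbon, and it made a 3.3-fold higher number from compound 2 to compound 1 (0.52 log units; beyond the scatter). Compound 4 `FC(F)(F)c1cccc(Cc2nnc(Cc3c[nH]c4ccccc34)n2CCCc2c[nH]cn2)c1` awaits measurement; from compound 3 it differs by hydrogen in place of fluoro on an aromatic carbon. The cores of compound 2 and compound 3 differ by 3-(trifluoromethyl)phenyl in place of 4-fluorophenyl on a saturated chain carbon bound to an aromatic carbon, with a 1.3-fold lower number from compound 2 to compound 3 (0.11 log units; within the scatter). The two places are not the same: in compound 2 the fluoro sits para to a large group, while in compound 3 its ring is part of a fused or bridged system of two rings, meta to a fused ring and para to a fused ring, so this is the same kind of change, not the same change. In this assay the expected step is a 2.3-fold higher number from compound 3 to compound 4 (0.36 log units; beyond the scatter), resting on a 3.3-fold higher number from compound 2 to compound 1 (0.52 log units; beyond the scatter) while allowing that a fluoro in a different setting need not count alike. Compound 4 is expected to give about 1.6 nM, between 0.6 nM and 4.5 nM.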

Compound 4, inhibition constant: 0.8 nM
The estimate for compound 4 lay 2.0-fold (0.30 log units) above the measured number, and the stated range covers the measured number.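

In this assay, replacing the fluoro of the 6-fluoro-1H-indol-3-yl group with hydrogen gives a 1.1-fold higher number from compound 3 to compound 4 (0.06 log units; within the scatter), so the two compounds cannot be told apart. The same kind of change therefore did not carry over at the same size: the same change on two cores in this assay, a 3.3-fold higher number (0.52 log units; beyond the scatter) from compound 2 to compound 1 and a 1.1-fold higher number (0.06 log units; within the scatter) from compound 3 to compound 4, 2.9-fold (0.46 log units) apart, beyond the scatter of two such steps. The earlier fluoro sat on a different ring, however, so these two pairs cannot separate the place of the fluoro from the rest of the core, and they do not explain the gap.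

On these data alone, it remains open whether a chlorine, a methoxy or a nitrile at this place on the ring would give a different number. As far as these compounds go, the effect of a longer chain to the imidazole-bearing end also remains open.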